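Swapping the Diethylaminoethyl Tail for a Phenyl Ring

A few compounds are considered here, and "the series" means these few. Any claim that something is new, unique, unknown or untested is made for them only; others in the source may bear on it.

Going by the values given here, compound 2 `CCN(CC)CCCNC1=Nc2ccc(Cl)cc2C(C)(C)C1` holds the lower of the two numbers so far: in a functional assay on MDA-MB-231 cells (Homo sapiens) for cytotoxicity, read by MTT assay, with a stated time of 72 h, tested at 1 uM, in the absence of a further agent (on this read-out lower numbers stand for a stronger effect and higher numbers for a weaker effect at the one concentration tested), compound 2 gives 53.3%, while compound 1 `CCCNC1=Nc2ccc(Cl)cc2C(C)(C)C1` gives 90.7%. Compound 3 `CC1(C)CC(NCc2ccccc2)=Nc2ccc(Cl)cc21` differs from compound 2 by phenyl in place of 2-(diethylamino)ethyl on a saturated chain carbon bound to an amine nitrogen. Among the compounds with values here, the one measured step bears on this directly: the diethylamino group that now leaves is the one that entered in a number 37.4 percentage points lower from compound 1 to compound 2 (beyond the scatter). Taking it away again, with phenyl arriving, is expected to push the number back up, roughly undoing that step, giving a number 31.7 percentage points higher from compound 2 to compound 3 (beyond the scatter). Compound 3 is therefore estimated at 85%, within 62% to 100%.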

Compound 3, a percentage reported as activity, at one concentration (the size of the read-out at that concentration, not a potency): 88.8%
Compound 3: the middle estimate sits 3.8 percentage points below what was measured; low and high end bracket the measured number.
By their numbers in this assay, from the lowest: compound 2; then compounds 3 and 1 (each within the scatter of the next).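

In this assay phenyl in place of 2-(diethylamino)ethyl on a saturated chain carbon bound to an amine nitrogen gives a number 35.5 percentage points higher from compound 2 to compound 3 (beyond the scatter) and so loses the stronger effect held by compound 2. Phenyl in place of ethyl on that same carbon gives a number 1.9 percentage points lower from compound 1 to compound 3 (within the scatter) and so separates the ring from the ethyl chain in no readable way. No measurement at hand explains either step. The compounds shown leave open whether the stronger effect needs the diethylamino group itself or would also come with another amine, such as morpholine, at the chain end. They also leave open whether a shorter or longer chain carrying diethylamino would do the same.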